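The compounds below may be only part of what the source reports. "The series", "measured", "known", "first", "only" and "open" are said of these compounds alone.

Compound 1 `Cc1ccc(S(=O)(=O)/N=C(/CCNC2=CC(=O)c3ccccc3C2=O)Nc2ccc(F)cc2)cc1` and compound 2 `Cc1ccc(S(=O)(=O)/N=C(/CCNC2=CC(=O)c3ccccc3C2=O)Nc2ccccc2I)cc1` share one core and differ only in the aromatic group attached to an amine nitrogen. In a functional assay on MCF7 cells (Homo sapiens) for cytotoxicity, read by MTT assay, with a stated time of 48 h (a higher number here means a weaker inhibitor, a lower number a stronger inhibitor), compound 1 gives 4260 nM, the lowest of the two numbers in hand, while compound 2 gives 15500 nM. The step of a 3.6-fold higher number from compound 1 to compound 2 (0.56 log units; beyond the scatter) runs toward weaker inhibition. Compound 3 `Cc1ccc(S(=O)(=O)/N=C(/CCNC2=CC(=O)c3ccccc3C2=O)Nc2cccc(C)c2)cc1` carries the change (3-methylphenyl in place of 4-fluorophenyl on an amine nitrogen). For the measured compounds named here, no measured pair shows exactly this change; the only step that bears on it, a 3.6-fold higher number from compound 1 to compound 2 (0.56 log units; beyond the scatter), replaced the same 4-fluorophenyl group with another aromatic ring and raised the number modestly. With that single guide, the step of a 1.3-fold higher number from compound 1 to compound 3 (0.11 log units; within the scatter) is expected to be small, and if anything to lean toward weaker inhibition, with a fair chance of staying within the scatter. Compound 3 is therefore estimated at 5500 nM, with a likely range from 2500 nM to 13000 nM.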

Compound 3, half-maximal inhibitory concentration: 8120 nM
Compound 3: the middle estimate sits 1.5-fold (0.17 log units) below what was measured, within the range that was stated.
By their numbers in this assay, from the lowest: compounds 1, 3 and 2 (each within the scatter of the next, the first and the last beyond it).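

In this assay, the 3-methylphenyl group on this amine nitrogen cannot be told apart from either earlier group: the swap gives a 1.9-fold higher number from compound 1 to compound 3 (0.28 log units; within the scatter), and from the other side a 1.9-fold lower number from compound 2 to compound 3 (0.28 log units; within the scatter). The one gap beyond the scatter, a 3.6-fold higher number from compound 1 to compound 2 (0.56 log units; beyond the scatter), now has a compound lying within the scatter of both ends, and this compound's ring carries no halogen, only carbon. No measurement of any property of these groups is at hand to account for the numbers.

Compound 3 differs from compound 1 both in the group on the ring and in where that group sits, so these two changes remain tangled; a 4-methylphenyl or a 3-fluorophenyl group would separate them. Also open, on these data alone, is whether a ring bearing a carboxylic acid or an amine would shift the number beyond the scatter.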